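Trading a methoxy-methylphenyl for a tert-butylphenyl on a urea-pyrimidine

The source may report more compounds than this note shows. Statements on the series, on what has been measured and on what is new or still open speak of the compounds shown alone.

Compound 1 `COc1cc(NC(=O)Nc2cc(Nc3ccc(OC)c(C)c3)ncn2)cc(OC)c1`: 62%
Compound 2 `Cc1ccc(Nc2cc(NC(=O)Nc3c(Cl)cccc3Cl)ncn2)cc1F`: 92%
Compound 3 `COc1cc(Nc2cc(NC(=O)Nc3c(Cl)cccc3Cl)ncn2)cc(OC)c1`: 90%

Of the compounds shown here, three have been tested in a functional assay on PC-9 cells (Homo sapiens) for inhibition, read by MTT assay, with a stated time of 48 h, tested at 10 uM; on this read-out lower numbers stand for less inhibition and higher numbers for more inhibition at the one concentration tested (going by the name of the read-out). Compound 1 gives 62%, the lowest of the three numbers. Compound 3 is nearest, and its number is higher by a gap beyond the scatter; compound 2 is furthest, and its number is higher by a gap also beyond the scatter. Going by the values given here, none of these three differ from one another in a single place, so no step between measured compounds can be read off.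

Compound 4 `COc1cc(NC(=O)Nc2cc(Nc3cccc(C(C)(C)C)c3)ncn2)cc(OC)c1` is not yet measured. It differs from compound 1 as follows: 3-(tert-butyl)phenyl in place of 4-methoxy-3-methylphenyl on a nitrogen on an aromatic ring. Among the compounds with values here, no measured pair tells how this kind of change moves the read-out. The step expected in this assay from compound 1 to compound 4 is therefore small and of uncertain direction, none beyond the scatter, as no change at the digits printed from compound 1 to compound 4 (within the scatter) shows. Compound 4 is estimated at 62%, between 42% and 82%.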

Compound 4, a percentage reported as inhibition, at one concentration (the size of the read-out at that concentration, not a potency): 68%
Beside the measured number, compound 4's estimate is 6 percentage points below it, and the stated range covers the measured number.
By their numbers in this assay, from the lowest: compounds 1 and 4 (each within the scatter of the next); then compounds 3 and 2 (each within the scatter of the next).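

On a nitrogen on an aromatic ring, putting 3-(tert-butyl)phenyl in place of 4-methoxy-3-methylphenyl gives, in this assay, a number 6 percentage points higher from compound 1 to compound 4 (within the scatter). This first single-place comparison shows that this position accepts an all-carbon group in place of one carrying oxygen, with no change that can be told from the scatter. No measurement of any other property bears on this step.

Still open, as far as these compounds go, is whether a group carrying an amine or a carboxylic acid at this position would move the read-out beyond the scatter. Also open, from the compounds shown here alone, is whether a smaller group, such as a plain phenyl, would behave the same way.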